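From a Difluorophenyl Amide to a Chlorophenyl Amide

This account rests on a few compounds, and the source may have more. Where it says the series, first, only, none or still open, it means among the compounds named here.

Compound 1 `CC(C)OC(=O)C1CN(C(=O)C2CCOCC2)CC(C)(C)c2cc(C#N)[nH]c21` gives > 100 ug/mL in a physicochemical assay for solubility, at pH 7.4 (a lower number here means a less soluble compound, a higher number a more soluble compound), which is a limit of the assay rather than a number.
Compound 2 `CC(C)OC(=O)C1CN(C(=O)c2ccc(F)c(F)c2)CC(C)(C)c2cc(C#N)[nH]c21` gives 31 ug/mL in this assay.

Compound 2 therefore holds the only number shown; the other value sits at the limit of > 100 ug/mL in this assay, at which 1 of the 2 values shown sits. Among the compounds with values here, the single measured step, an at least 3.2-fold lower number from compound 1 to compound 2 (0.50 log units; beyond the scatter), exchanged oxan-4-yl for an aryl group. Compound 3 `CC(C)OC(=O)C1CN(C(=O)c2ccc(Cl)cc2)CC(C)(C)c2cc(C#N)[nH]c21` differs from compound 2 by 4-chlorophenyl in place of 3,4-difluorophenyl on a carbonyl carbon. Within the data shown here, no measured step exchanges one aryl group for another, so that step bears on this change only loosely. The number is expected to move little, a 1.4-fold lower number from compound 2 to compound 3 (0.15 log units; within the scatter). Compound 3 is expected to give 22 ug/mL, between 8 ug/mL and 55 ug/mL.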

Compound 3, solubility: 5 ug/mL
The estimate for compound 3 lay 4.4-fold (0.64 log units) above the measured number, outside the stated range (below it).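

In this assay, the position on the carbonyl carbon distinguishes even one aryl group from another: 4-chlorophenyl in place of 3,4-difluorophenyl gives a 6.2-fold lower number from compound 2 to compound 3 (0.79 log units; beyond the scatter). Measured against oxan-4-yl, the same group gives an at least 20-fold lower number from compound 1 to compound 3 (1.30 log units; beyond the scatter). Compound 1 stands at > 100 ug/mL in this assay, which is a limit of the assay and not a number.

Nothing shown accounts for the step between the two aryl groups. From the compounds shown here alone, whether a pyridine ring or a morpholine on the same carbonyl carbon would fall with the aryl groups or with oxan-4-yl stays open.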